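Methyl in Place of 4-Fluorophenyl on the Chain

The source may hold more compounds than are shown below. What is called first, only, known or untested is meant among the compounds shown, and "the series" means these compounds.

Measured compounds:
- compound 1 `CN1CCC(c2ccc3c(c2)oc(=O)n3C(=O)NCCCCc2ccc(F)cc2)CC1`: 0.5 h
- compound 2 `CN1CCC(c2cc3oc(=O)n(C(=O)NCCCCc4ccccc4)c3cc2F)CC1`: > 1 h

In an ADME assay on microsomes from liver (Mus musculus) for metabolic stability, read by LC-MS, using NADPH, with stated times of 15 min and 60 min, tested at 4.6 uM (a lower number here means that the compound disappears faster, a higher number that the compound lasts longer), compound 1 gives 0.5 h, the only plain number shown. Compound 2 reaches (the limit of > 1 h in this assay, at which 1 of the 2 values shown sits). Compound 3 `CCCCCNC(=O)n1c(=O)oc2cc(C3CCN(C)CC3)ccc21` has not yet been measured; it differs from compound 1 by methyl in place of 4-fluorophenyl on a saturated chain carbon, four bonds along the chain from an amide-type nitrogen. Going by the values given here, no measured pair shows this change, so its effect is uncertain. A step from compound 1 to compound 3 of a 1.7-fold lower number from compound 1 to compound 3 (0.22 log units; within the scatter) is expected, downward and beyond the usual scatter. Compound 3 is estimated at 0.3 h, within a range from 0.12 h to 0.8 h.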

Compound 3, half-life: > 1 h
Compound 3 ended at the assay's limit; the forecaster's own chance of this, stated with the estimate: 5%; middle value at least 3.3-fold (0.52 log units) away from the limit.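

Methyl in place of 4-fluorophenyl on this chain gives, in this assay, an at least 2.0-fold higher number from compound 1 to compound 3 (0.30 log units; that floor lies within the scatter). The 4-fluorophenyl is therefore not needed for a compound of this series to last this long. The value of compound 3 is a limit, so the true size of the step cannot be read: the limit of > 1 h in this assay, at which 2 of the 3 values shown sit.

From the compounds shown here alone, it remains open whether a cyclohexyl at this place would last as long as methyl, which would help separate the aromatic ring from the size of the group. Going by these compounds, how far compound 3 lies past its limit also stays unknown.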